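Aminopyridyl variant of a pyrazolopyrimidine corticotropin-releasing factor ligand

The source may hold more compounds than are shown below. What is called first, only, known or untested is meant among the compounds shown, and "the series" means these compounds.

Compound 1 `CCCN(CCC)c1cc(C)nc2c(-c3ccc(Cl)cn3)c(C)nn12`: 88 nM
Compound 2 `CCCN(CCC)c1cc(C)nc2c(-c3ncc(C)cc3[N+](=O)[O-])c(C)nn12`: 14 nM

Of the compounds shown here, two have been measured in an assay on isolated protein for binding affinity to corticotropin-releasing factor receptor 1 (Homo sapiens); a lower number here means a stronger inhibitor, a higher number a weaker inhibitor. Compound 1 gives 88 nM, which is the higher of the two numbers. Its nearest neighbour is compound 2, whose value of 14 nM lies beyond the usual scatter of this assay, so compound 1 stands as the weaker of the measured pair.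

The unmeasured compound 3 `CCCN(CCC)c1cc(C)nc2c(-c3ncc(NC)cc3C)c(C)nn12` arises from compound 1 by a single change: 3-methyl-5-(methylamino)pyridin-2-yl in place of 5-chloropyridin-2-yl on an aromatic carbon. For the measured compounds named here, no step between two measured compounds matches this change, so no measured guide for it exists. Compound 2 shows that a substituted pyridyl on the same aromatic carbon of the shared core can give a lower number than compound 1, but the groups on its ring differ from those of compound 3, and nothing further can be drawn from it.

Compound 3 is therefore expected to give 50 nM in this assay, within a range of 10 nM to 250 nM. The step from compound 1 to compound 3 is estimated as a 1.8-fold lower number from compound 1 to compound 3 (0.25 log units; within the scatter), a modest move toward a lower number, though one that may not exceed the scatter.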

Compound 3, inhibition constant: 40 nM
Compound 3: middle estimate off by 1.3-fold (0.10 log units), on the high side; measured number inside the range.
By their numbers in this assay, from the lowest: compound 2; then compound 3; then compound 1.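

In this assay, putting 3-methyl-5-(methylamino)pyridin-2-yl in place of 5-chloropyridin-2-yl on this aromatic carbon gives a 2.2-fold lower number from compound 1 to compound 3 (0.34 log units; beyond the scatter), a modest step that still lies beyond the usual scatter. For the compounds shown here, this is the first measured step at this position, and it shows that the position accepts a larger pyridyl group that has lost its chlorine and gained both a methyl group and a methylamino group, with a hydrogen-bond donor that the leaving group lacks, without any rise in the number. No measurement shown here accounts for the lower number of compound 3.

The change alters the pyridyl ring in more than one way, and the compounds shown do not separate the loss of the chlorine from the gain of the methyl group or the methylamino group. They also leave open how the number would move with a primary amine, a dimethylamino group or a methoxy group in place of the methylamino group, or with a pyridyl ring that carries the methylamino group but no methyl group.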